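The compounds below may be only part of what the source reports. "The series", "measured", "known", "first", "only" and "open" are said of these compounds alone.

Two relatives with the same core have been tested so far, compound 1 (`COc1ccc(CNc2ncnc3c2ncn3C2CCCCO2)cc1OC`) and compound 2 (`COc1cc(CNc2ncnc3c2ncn3C2CCCCO2)cc(OC)c1`). In an ADME assay on MCF7 cells (Homo sapiens) for cytotoxicity, with a stated time of 72 h (on this read-out lower numbers stand for stronger inhibition and higher numbers for weaker inhibition), compound 1 gives > 100000 nM, which is a limit of the assay and not a number. Compound 2 gives > 100000 nM in this assay, and this too is a limit. Compound 2 therefore has no exact number to stand on, and the record so far is the limit of > 100000 nM in this assay, at which 2 of the 2 values shown sit.

Compound 3 (`COc1cc(CNc2ncnc3c2ncn3C2CCCCO2)cc(OC)c1OC`) comes from compound 2 by a single change: methoxy in place of hydrogen on an aromatic carbon. A methoxy takes the place of a hydrogen on an aromatic carbon, ortho to two methoxy groups and para to a large group.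

Within the data shown here, no measured pair shows what such a change does in this assay, so the expectation rests on the two limits alone. Little or no movement beyond the scatter is expected, and compound 3 may well end at the same limit. The estimated change is a number no higher from compound 2 to compound 3 (the limit leaves the size open). For compound 3 the expected value is 100000 nM, with an estimated range from 30000 nM to 200000 nM.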

Compound 3, half-maximal inhibitory concentration: > 100000 nM
Compound 3 was reported as a limit; the forecaster's own chance of this, stated with the estimate: 75%; the middle value sits exactly at the limit.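

Compound 3 is a limit of the assay and not a number, like compound 1 and compound 2, so neither the step from compound 1 to compound 3 nor the step from compound 2 to compound 3 can be read: the limit of > 100000 nM in this assay, at which 3 of the 3 values shown sit. From the compounds shown here alone, what remains open is how strongly any of the three acts in this assay and whether the added methoxy makes any difference there.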